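The source may hold more compounds than are shown below. What is called first, only, known or untested is meant among the compounds shown, and "the series" means these compounds.

Compound 1 `COc1ccc(-n2ccc(=O)c(C(=O)Nc3ccc(Oc4ccnc5[nH]ccc45)c(F)c3)n2)cc1` carries a core that is joined in compound 2 `COc1ccc(-n2ccc(=O)c(C(=O)Nc3ccc(Oc4ccnc5c4ccn5C)c(F)c3)n2)cc1` to the same outer parts, with one change: methyl in place of hydrogen on an aromatic nitrogen. In a functional assay on MCF7 cells (Homo sapiens) for cytotoxicity, read by MTT assay, with a stated time of 72 h (a higher number here means a weaker inhibitor, a lower number a stronger inhibitor), compound 1 gives 55400 nM. For compound 2 the value in this assay is only a limit of the assay, > 60000 nM. The step is an at least 1.0-fold higher number from compound 1 to compound 2 (0.03 log units; that floor lies within the scatter), and the limit itself stands as the limit of > 60000 nM in this assay, at which 1 of the 3 values shown sits.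

Compound 3 `Cc1cc(=O)n(-c2ccccc2OC(F)(F)F)nc1C(=O)Nc1ccc(Oc2ncnc3[nH]ccc23)cc1` is built on a different core; how the two cores differ is not broken down here. In this assay compound 3 gives 32000 nM, a number that sits within the scatter of the value of compound 1.

Compound 4 `Cc1cc(=O)n(-c2ccccc2OC(F)(F)F)nc1C(=O)Nc1ccc(Oc2ncnc3c2ccn3C)cc1`, not yet measured, arises from compound 3 by the same change seen between compound 1 and compound 2: methyl in place of hydrogen on an aromatic nitrogen. The place described for both changes is the same, so this is expected to behave alike. On that basis the expected step is a 1.4-fold higher number from compound 3 to compound 4 (0.15 log units; within the scatter), resting on the measured step from compound 1 to compound 2. Compound 4 is therefore estimated at 45000 nM in this assay, expected to fall between 18000 nM and 110000 nM.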

Compound 4, half-maximal inhibitory concentration: 27000 nM
The estimate for compound 4 lay 1.7-fold (0.22 log units) above the measured number, and the stated range covers the measured number.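

In this assay, methyl in place of hydrogen on an aromatic nitrogen gives a 1.2-fold lower number from compound 3 to compound 4 (0.07 log units; within the scatter), so on this core the change leaves the number within the usual scatter. Set beside the earlier case, the two cores compare only this far: the same change on two cores in this assay, an at least 1.0-fold higher number (0.03 log units; that floor lies within the scatter) from compound 1 to compound 2 and a 1.2-fold lower number (0.07 log units; within the scatter) from compound 3 to compound 4; the limit leaves it open whether they differ. The value of compound 2 is only a limit of the assay, and the two pairs show neither that the change acts alike on the two cores nor that it acts differently.

The compounds shown leave open whether a different group on that aromatic nitrogen, such as a longer chain, a chain ending in an amine or one ending in a carboxylic acid, would move the number beyond the scatter. All four compounds are also seen in this one assay on one cell line, so how the change behaves in any other read-out remains an open question.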